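Amide-chain amine variants in the shared core series

The compounds below may be only part of what the source reports. "The series", "measured", "known", "first", "only" and "open" are said of these compounds alone.

Compound 1 `COc1ccc(-c2cc3ccc(OC)cc3nc2Nc2ccc(NC(=O)CN(C)C)cc2)cc1` in a functional assay on MCF7 cells (Homo sapiens) for antiproliferative activity, read by MTT assay, with a stated time of 48 h (a lower number here means a stronger inhibitor, a higher number a weaker inhibitor), gives 9600 nM. Within the data shown here, compound 2 `CCN(CC)CC(=O)Nc1ccc(Nc2nc3cc(OC)ccc3cc2-c2ccc(OC)cc2)cc1` gives 17300 nM, the highest of the two numbers measured so far; the step of a 1.8-fold higher number from compound 1 to compound 2 (0.26 log units; within the scatter) stays within the scatter. Compound 3 `COc1ccc(-c2cc3ccc(OC)cc3nc2Nc2ccc(NC(=O)CN3CCCC3)cc2)cc1` differs from compound 2 by pyrrolidin-1-yl in place of diethylamino on a saturated chain carbon bound to a carbonyl carbon. Among the measured compounds shown here, only the step from compound 1 to compound 2 bears on this change, and it was small, so no step beyond the scatter is expected in this assay; the expected step is a 1.4-fold lower number from compound 2 to compound 3 (0.16 log units; within the scatter). Compound 3 is therefore estimated at 12000 nM, with a range from 5000 nM to 30000 nM.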

Compound 3, half-maximal inhibitory concentration: 6600 nM
Compound 3: the middle estimate sits 1.8-fold (0.26 log units) above what was measured, within the range that was stated.
By their numbers in this assay, from the lowest: compounds 3, 1 and 2 (each within the scatter of the next, the first and the last beyond it).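

Pyrrolidin-1-yl in place of diethylamino on a saturated chain carbon bound to a carbonyl carbon gives the first step at this position beyond the scatter in this assay: a 2.6-fold lower number from compound 2 to compound 3 (0.42 log units; beyond the scatter). Pyrrolidin-1-yl in place of dimethylamino stays within the scatter, with a 1.5-fold lower number from compound 1 to compound 3 (0.16 log units; within the scatter), so among these three amines only compound 2 and compound 3 are separated. Nothing measured on these compounds accounts for this step.

Still open, going by these compounds, is how piperidin-1-yl or morpholin-4-yl would behave here. On these data alone, a longer chain carrying the amine is equally open.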